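The source may report more compounds than this note shows. Statements on the series, on what has been measured and on what is new or still open speak of the compounds shown alone.

Measured in a functional assay on BaF3 cells (Mus musculus) for antiproliferative activity; on this read-out higher numbers stand for an effect only at larger amounts of compound and lower numbers for an effect already at smaller amounts:
- compound 1 `CCN1CCN(Cc2ccc(NC(=O)c3ccc(C)c(C#Cc4ccc(NC(C)=O)nc4)c3)cc2C(F)(F)F)CC1`: 2050 nM
- compound 2 `CCN1CCN(Cc2ccc(NC(=O)c3ccc(C)c(C#Cc4cnc5[nH]ccc5c4)c3)cc2C(F)(F)F)CC1`: 1000 nM
- compound 3 `CCN1CCN(Cc2ccc(NC(=O)c3ccc(C)c(C#Cc4cnc5[nH]c(C)cc5c4)c3)cc2C(F)(F)F)CC1`: 1000 nM

Compound 3 stands level with compound 2, and together they hold the lowest of the three numbers. Compound 1 lies above both.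

The next compound is compound 4 `CCN1CCN(Cc2ccc(NC(=O)c3ccc(C)c(C#Cc4cnc5nccnc5c4)c3)cc2C(F)(F)F)CC1`, still to be measured. It differs from compound 3 by a group of 10 heavy atoms (7 carbon, 3 nitrogen; one six-membered aromatic ring with 1 hetero atom, one six-membered aromatic ring with 2 hetero atoms) in place of a group of 10 heavy atoms (8 carbon, 2 nitrogen; one five-membered aromatic ring with 1 hetero atom, one six-membered aromatic ring with 1 hetero atom), on a triple-bonded carbon, and the change sits on a triple-bonded carbon.

Among the compounds with values here, three measured steps bear on this, since each changes the group at that same place. The first is a 2.1-fold lower number from compound 1 to compound 2 (0.31 log units; beyond the scatter) and the second is a 2.1-fold lower number from compound 1 to compound 3 (0.31 log units; beyond the scatter), both modest. The third, no change at the digits printed from compound 2 to compound 3 (within the scatter), involves only a methyl in place of hydrogen on an aromatic carbon. So far, then, replacing this group has moved the number only slightly. Within the data shown here, no measured compound carries the entering group, however, so the direction of the step is poorly defined and the range has to stay wide.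

No step beyond the scatter is therefore expected. The estimated step is a 1.3-fold higher number from compound 3 to compound 4 (0.11 log units; within the scatter), a small one with no firm direction. For compound 4 the expected value is 1300 nM, with an estimated range from 450 nM to 3800 nM.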

Compound 4, half-maximal effective concentration: 3320 nM
Compound 4: middle estimate off by 2.6-fold (0.41 log units), on the low side; measured number inside the range.
By their numbers in this assay, from the lowest: compounds 2 and 3 (each within the scatter of the next); then compounds 1 and 4 (each within the scatter of the next).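

The group on the triple-bonded carbon can shift the number in this assay in the upward direction: replacing the group with one five-membered and one six-membered aromatic ring by the group with two six-membered aromatic rings gives a 3.3-fold higher number from compound 3 to compound 4 (0.52 log units; beyond the scatter), and the same exchange for the smaller, unmethylated group gives a 3.3-fold higher number from compound 2 to compound 4 (0.52 log units; beyond the scatter). Against the group carrying oxygen the entering group stays within the scatter, with a 1.6-fold higher number from compound 1 to compound 4 (0.21 log units; within the scatter), so across these four compounds the two with a five-membered aromatic ring, compound 2 and compound 3, hold the lower numbers, and neither compound 1 nor compound 4 goes against this split. Nothing measured here gives a reason for the rise on this exchange.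

The step from compound 3 to compound 4 changes ring size, nitrogen count, hydrogen-bond donors and hydrogen-bond acceptors at once, so the compounds shown do not tell which of these carries the rise. Also open, as far as these compounds go, is how a group such as a simple phenyl ring, or a six-membered aromatic ring bearing an amine, would read at this triple-bonded carbon.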